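The compounds below may be only part of what the source reports. "The series", "measured", "known", "first", "only" and "open" are said of these compounds alone.

Compound 2 `CS(=O)(=O)c1ccc2c(c1)CCN2c1ncnc2c(C3CCN(c4ncc(Cl)cn4)CC3)coc12` gives 117% in a functional assay on cells for agonist activity at Glucose-dependent insulinotropic receptor (Homo sapiens), read by a luciferase reporter, with a stated time of 4 h (on this read-out higher numbers stand for larger maximal responses and lower numbers for smaller maximal responses), and stands highest of the two numbers; compound 1 `CC(O)c1cnc(N2CCC(c3coc4c(N5CCc6cc(S(C)(=O)=O)ccc65)ncnc34)CC2)nc1` gives 33%. For the measured compounds named here, the only measured step, a number 84 percentage points higher from compound 1 to compound 2 (beyond the scatter), concerns the group on the aromatic ring at the ring amine. Compound 3 `CC(C)(C)OC(=O)N1CCC(c2coc3c(N4CCc5cc(S(C)(=O)=O)ccc54)ncnc23)CC1` differs from compound 2 by tert-butoxycarbonyl in place of 5-chloropyrimidin-2-yl on an amine nitrogen in a ring. Going by the values given here, that same region is altered here, and the measured step shows it matters, but no step with an aromatic ring removed exists, so the direction is uncertain and a loss is expected. The expected step is a number 77 percentage points lower from compound 2 to compound 3 (beyond the scatter). Compound 3 is therefore estimated at 40%, in the range 5% to 100%.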

Compound 3, largest response reached (Emax), in percent of the reference or control that the assay uses: 123%
Compound 3: the middle estimate sits 83 percentage points below what was measured; measured number outside the range, above it.
By their numbers in this assay, from the lowest: compound 1; then compounds 2 and 3 (each within the scatter of the next).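

The step of a number 6 percentage points higher from compound 2 to compound 3 (within the scatter) in this assay shows that the amine nitrogen in the six-membered ring need not carry an aromatic ring: tert-butoxycarbonyl, which has no ring, serves as well as 5-chloropyrimidin-2-yl. The step of a number 90 percentage points higher from compound 1 to compound 3 (beyond the scatter) sets 5-(1-hydroxyethyl)pyrimidin-2-yl apart from both other groups at this position. Nothing available explains either result.

Still open, from the compounds shown here alone, is whether a smaller methoxycarbonyl, an acetyl amide or the free ring amine at this nitrogen keeps the response.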